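Dienone series: quinoline core variants, cytotoxicity on 4T1 cells

The compounds below may be only part of what the source reports. "The series", "measured", "known", "first", "only" and "open" are said of these compounds alone.

Measured compounds:
- compound 1, `COc1ccc(/C=C/C(=O)/C=C/c2cc3ccccc3nc2Cl)cc1`: > 10000 nM
- compound 2, `COc1ccc(/C=C/C(=O)/C=C/c2cc3ccccc3nc2Cl)c(OC)c1`: > 10000 nM
- compound 3, `COc1ccc(/C=C/C(=O)/C=C/c2cc3ccccc3nc2Oc2ccccc2)cc1`: > 10000 nM

In a functional assay on 4T1 cells (Mus musculus) for cytotoxicity, read by MTT assay, with a stated time of 48 h (a lower number here means a stronger inhibitor, a higher number a weaker inhibitor), compound 1 reaches only the limit > 10000 nM. For compound 2 the same assay also gives only a limit, > 10000 nM. Compound 3 likewise stops at a limit, > 10000 nM. Hence the step that the two limits leave unreadable from compound 1 to compound 2, the change (methoxy in place of hydrogen on an aromatic carbon), cannot be sized, and the same holds for a step that the two limits leave unreadable from compound 1 to compound 3, the core change (phenoxy in place of chloro on an aromatic carbon); all three sit at the limit of > 10000 nM in this assay, at which 3 of the 3 values shown sit.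

Compound 4, `COc1ccc(/C=C/C(=O)/C=C/c2cc3ccccc3nc2Oc2ccccc2)c(OC)c1`, remains to be measured in this assay. It differs from compound 3 by methoxy in place of hydrogen on an aromatic carbon, the same change as from compound 1 to compound 2, where both ends were limits. With no readable step available, compound 4 is expected to show a step that the limit leaves unreadable from compound 3 to compound 4, i.e. to remain near the limit as well. Compound 4 is estimated at 15000 nM, within 5000 nM to 60000 nM.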

Compound 4, half-maximal inhibitory concentration: > 10000 nM
Compound 4 ended at the assay's limit; the forecaster's own chance of this, stated with the estimate: 85%; the middle value lies beyond the limit too.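

Neither the step from compound 3 to compound 4 nor the one from compound 2 to compound 4 can be read, as both ends of each are limits: the limit of > 10000 nM in this assay, at which 4 of the 4 values shown sit.

The compounds shown leave open which change, if any, would bring a value inside the measurable range of this assay.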